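A few compounds are considered here, and "the series" means these few. Any claim that something is new, unique, unknown or untested is made for them only; others in the source may bear on it.

Compound 1 `Cc1nnc(SCC(=O)N/N=c2/scc(-c3ccc(F)cc3)n2-c2ccccc2)s1` is tested in a functional assay on C6 cells (Rattus norvegicus) for cytotoxicity, read by MTT assay, with a stated time of 24 h, tested at 12 ug/mL (on this read-out higher numbers stand for a weaker effect at the one concentration tested and lower numbers for a stronger effect), where compound 1 gives 73.7%. Compound 2 `Cc1nnc(SCC(=O)N/N=c2/scc(-c3ccc(Cl)cc3)n2-c2ccccc2)s1` differs from it by chloro in place of fluoro on an aromatic carbon, and in this assay compound 2 gives 76.6%, a step of a number 2.9 percentage points higher from compound 1 to compound 2 (within the scatter). Compound 3 `O=C(CSc1nnnn1-c1ccccc1)N/N=c1/scc(-c2ccc(F)cc2)n1-c1ccccc1` carries a different core, the difference being (1-phenyl-1H-tetrazol-5-yl in place of 5-methyl-1,3,4-thiadiazol-2-yl on a sulfur); in this assay compound 3 gives 60%, which is a number 13.7 percentage points lower from compound 1 to compound 3 (beyond the scatter). Compound 4 `O=C(CSc1nnnn1-c1ccccc1)N/N=c1/scc(-c2ccc(Cl)cc2)n1-c1ccccc1` has not yet been measured. It differs from compound 3 by chloro in place of fluoro on an aromatic carbon, the same change that led from compound 1 to compound 2. Because that earlier change gave a number 2.9 percentage points higher from compound 1 to compound 2 (within the scatter), compound 4 is expected to sit close to compound 3, with an estimated step of a number 3 percentage points higher from compound 3 to compound 4 (within the scatter) in this assay. The estimate for compound 4 in this assay is 63%, expected between 50% and 76%.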

Compound 4, a percentage reported as activity, at one concentration (the size of the read-out at that concentration, not a potency): 69.3%
Compound 4: the middle estimate sits 6.3 percentage points below what was measured; the measured number falls inside the stated range.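

In this assay, chloro in place of fluoro on the core bearing the 1-phenyl-1H-tetrazol-5-yl group gives a number 9.3 percentage points higher from compound 3 to compound 4 (within the scatter), and this step agrees with the one on the other core: the same change on two cores in this assay, a number 2.9 percentage points higher (within the scatter) from compound 1 to compound 2 and a number 9.3 percentage points higher (within the scatter) from compound 3 to compound 4, 6.4 percentage points apart, within the scatter of two such steps. The exchange of 5-methyl-1,3,4-thiadiazol-2-yl for 1-phenyl-1H-tetrazol-5-yl, with chloro on the aromatic ring, gives a number 7.3 percentage points lower from compound 2 to compound 4 (within the scatter), and it also agrees with its earlier counterpart: the same change on two cores in this assay, a number 13.7 percentage points lower (beyond the scatter) from compound 1 to compound 3 and a number 7.3 percentage points lower (within the scatter) from compound 2 to compound 4, 6.4 percentage points apart, within the scatter of two such steps. Going by these compounds alone, this agreement rests on only two pairs per change and does not show that the halogen exchange has any real effect, nor that the heterocycle exchange does so in the chloro pair.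

Going by these compounds, whether a methoxy or nitro group in place of the halogen, or a longer chain on the sulfur, would change this read-out remains open. So does how the effects of these compounds compare at any other concentration: the read-out comes from a single concentration and shows only a stronger or weaker effect there.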